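A few compounds are considered here, and "the series" means these few. Any claim that something is new, unique, unknown or untested is made for them only; others in the source may bear on it.

Measured so far in a toxicity assay on THP-1 cells (Homo sapiens) for inhibition; on this read-out lower numbers stand for higher toxicity in this test and higher numbers for lower toxicity in this test:
compound 1 `COc1ccc(-c2cnc(NC(=O)c3ccc(Br)cc3)n2C)cc1` gives > 100000 nM, which is a limit of the assay and not a number.
compound 2 `COc1ccc(-c2cnc(NC(=O)c3cccc(Cl)c3)n2C)cc1` gives > 28000 nM, likewise a limit rather than a number.

Both values shown sit at limits the limit of > 100000 nM in this assay, at which 1 of the 2 values shown sits (the limit of > 28000 nM in this assay, at which 1 of the 2 values shown sits), so compound 2 can only be placed at or beyond its own limit, with no measured number to set it against. Within the data shown here, the step that the two limits leave unreadable from compound 1 to compound 2 is the only measured step between these compounds, and the two limits leave its size unreadable. Compound 3 `COc1ccc(-c2cnc(NC(=O)c3ccc(C#N)cc3)n2C)cc1` differs from compound 2 in one place: 4-cyanophenyl in place of 3-chlorophenyl on a carbonyl carbon. Among the measured compounds shown here, no measured step shows what a change of this kind does here, so the expected step that the limit leaves unreadable from compound 2 to compound 3 rests only on the two limits and is expected to stay within the scatter. Compound 3 is therefore estimated at 100000 nM in this assay, with a range from 28000 nM to 300000 nM, and is most likely to be reported again as a limit.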

Compound 3, half-maximal cytotoxic concentration: > 100000 nM
Compound 3: a limit, no number; the forecaster's own chance of this, stated with the estimate: 80%; the middle value lies on the limit itself.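

Compound 1, compound 2 and compound 3 all give limits rather than numbers, so the steps between them cannot be read. The compounds shown leave open whether any change on the carbonyl carbon shifts the half-maximal cytotoxic concentration in this assay.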